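A Tetrazole in Place of the Furan on Compound 2

The source may report more compounds than this note shows. Statements on the series, on what has been measured and on what is new or still open speak of the compounds shown alone.

In a functional assay (aorta) with Oryctolagus cuniculus as the target (a higher number here means a weaker inhibitor, a lower number a stronger inhibitor), compound 2 `Fc1ccccc1Cn1nc(-c2ccco2)c2cccnc21` gives 9300 nM. Of the three measured numbers, the nearest belongs to compound 3 `NS(=O)(=O)c1ccc(-c2nn(Cc3ccccc3F)c3ncccc23)o1` with 8000 nM, and the furthest to compound 1 `OCc1ccc(-c2nn(Cc3ccc(F)cc3)c3ccccc23)o1` with 19000 nM, which is the higher of the two. Among the measured compounds shown here, the only step measured in one place is a 1.2-fold lower number from compound 2 to compound 3 (0.07 log units; within the scatter). Compound 4 `Fc1ccccc1Cn1nc(-c2nn[nH]n2)c2cccnc21` differs from compound 2 by 2H-tetrazol-5-yl in place of furan-2-yl on an aromatic carbon. For the measured compounds named here, no measured step touches this part of the structure, so the expectation rests on compound 2 alone, and a 1.3-fold higher number from compound 2 to compound 4 (0.11 log units; within the scatter) is expected to lie within the scatter. Compound 4 is therefore estimated at 12000 nM, with a range from 3000 nM to 50000 nM.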

Compound 4, half-maximal inhibitory concentration: 8600 nM
The estimate for compound 4 lay 1.4-fold (0.14 log units) above the measured number; the range from low to high includes it.
By their numbers in this assay, from the lowest: compounds 3, 4 and 2 (each within the scatter of the next); then compound 1.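

Among the compounds shown here, this is the first measured step at this position: in this assay, 2H-tetrazol-5-yl in place of furan-2-yl gives a 1.1-fold lower number from compound 2 to compound 4 (0.03 log units; within the scatter), even though the entering ring carries four hetero atoms against one, plus a hydrogen-bond donor that furan-2-yl lacks. In this single pair, those differences in counts leave the number within the scatter. Nothing available explains this result. As far as these compounds go, whether a carboxylic acid or an amine on this aromatic carbon would also stay within the scatter of compound 2 remains open. So does whether the same exchange would behave alike on the core of compound 1.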